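Double-bond geometry change on the shared core

The compounds below may be only part of what the source reports. "The series", "measured", "known", "first", "only" and "open" are said of these compounds alone.

Three compounds carry the shared core with an acetoxymethyl arm. Compound 1 `CC(=O)OC/C(=C\c1ccc(Cl)cc1)C(=O)c1ccccc1` gives 2600 nM in a functional assay on SW1573 cells (Homo sapiens) for inhibition, read by sulforhodamine B assay, with a stated time of 48 h; on this read-out lower numbers stand for stronger inhibition of growth and higher numbers for weaker inhibition of growth. Compound 2 `CC(=O)OC/C(=C\c1ccc(Cl)cc1Cl)C(=O)c1ccccc1` gives 3500 nM, and compound 3 `CC(=O)OC/C(=C\c1ccc(Cl)cc1Cl)C(=O)c1ccc(Cl)cc1` gives 3400 nM. Compound 2 holds the highest of the three numbers, yet the step of a 1.3-fold higher number from compound 1 to compound 2 (0.13 log units; within the scatter) and the step of a 1.0-fold lower number from compound 2 to compound 3 (0.01 log units; within the scatter) both sit within the scatter, so the three values are indistinguishable here. Compound 4 `CC(=O)OC/C(=C/c1ccc(Cl)cc1Cl)C(=O)c1ccccc1` differs from compound 2 as follows: the two compounds have the same atoms and bonds and differ only in configuration as drawn: 1 of 1 stereo elements differ; a double bond is drawn E in compound 2 and Z in compound 4. Among the measured compounds shown here, no measured step involves a change of geometry; the two known steps are chloro for hydrogen only and do not bear on this change. Without a relevant step, the expected move for compound 4 is no change at the digits printed from compound 2 to compound 4 (within the scatter), nothing beyond the scatter, with a broad range. Compound 4 is estimated at 3500 nM, between 1200 nM and 10000 nM.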

Compound 4, concentration for 50% growth inhibition: 22000 nM
For compound 4 the middle estimate is 6.3-fold (0.80 log units) below the measured one; measured number above the stated range.
By their numbers in this assay, from the lowest: compounds 1, 3 and 2 (each within the scatter of the next); then compound 4.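

In this assay, double-bond geometry is the only change shown that moves the number beyond the scatter: a 6.3-fold higher number from compound 2 to compound 4 (0.80 log units; beyond the scatter). The chloro for hydrogen steps stayed within the scatter, so in this one pair the geometry matters more than either chloro change. The step can be assigned to the double bond alone, because nothing else differs: the fact that compounds 2 and 4 differ only in the configuration as drawn

As far as these compounds go, whether the same step holds for the Z forms of compound 1 and compound 3 stays open. Also open, from the compounds shown here alone, is how an amine or a carboxylic acid in place of the acetoxymethyl arm would read under either geometry.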